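The source may report more compounds than this note shows. Statements on the series, on what has been measured and on what is new or still open speak of the compounds shown alone.

Three close analogues share one core, and a fourth is still to be tested. Compound 1 is `CNC(=O)c1cc(Oc2ccc3nc(Nc4cccc(Br)c4)ncc3c2)ccn1`. Compound 2 is `CNC(=O)c1cc(Oc2ccc3nc(Nc4cccc(C(F)(F)F)c4)ncc3c2)ccn1`, reached from compound 1 by the change (trifluoromethyl in place of bromo on an aromatic carbon). Compound 3 is `CNC(=O)c1cc(Oc2ccc3nc(Nc4ccc(Br)cc4)ncc3c2)ccn1`, which differs from compound 1 in 4-bromophenyl in place of 3-bromophenyl on a nitrogen on an aromatic ring. Compound 4 is `CNC(=O)c1cc(Oc2ccc3nc(Nc4ccc(C(F)(F)F)cc4)ncc3c2)ccn1`.

In an ADME assay on Caco-2 cells (Homo sapiens) for permeability, in the apical to basolateral direction (a higher number here means that the compound crosses the layer faster, a lower number that the compound crosses the layer more slowly), compound 1 gives < 1 10^-6 cm/s, which is a limit of the assay rather than a number. In this assay compound 2 gives < 1 10^-6 cm/s, again a limit. In this assay compound 3 gives < 1 10^-6 cm/s, also a limit. Because all three sit at the limit of < 1 10^-6 cm/s in this assay, at which 3 of the 3 values shown sit, the step that the two limits leave unreadable from compound 1 to compound 2 cannot be read, and neither can a step that the two limits leave unreadable from compound 1 to compound 3 or a step that the two limits leave unreadable from compound 2 to compound 3.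

Compound 4 arises from compound 3 by trifluoromethyl in place of bromo on an aromatic carbon, the same kind of change as from compound 1 to compound 2, though the surroundings differ: meta to a large group there, para to a large group here. The expectation for compound 4 rests only on compound 3 lying at its limit < 1 10^-6 cm/s. The step expected from that limit, a step that the limit leaves unreadable from compound 3 to compound 4, is small. Compound 4 is therefore estimated at 0.7 10^-6 cm/s, between 0.2 10^-6 cm/s and 2.5 10^-6 cm/s.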

Compound 4, apparent permeability in the Caco-2 assay: < 1 10^-6 cm/s
Compound 4 gave a limit, no number (the forecaster's own chance of this, stated with the estimate: 65%); the middle value does not contradict the limit.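

For the compounds shown here, in the Caco-2 assay compound 4 also gives only a limit, so no step from compound 1, compound 2 or compound 3 to compound 4 can be read: the limit of < 1 10^-6 cm/s in the Caco-2 assay, at which 4 of the 4 values shown sit. In a physicochemical assay for solubility, at pH 7 (on this read-out higher numbers stand for higher solubility and lower numbers for lower solubility), compound 3 gives < 1000 nM, which is a limit. In the physicochemical assay compound 4 gives < 1000 nM, also a limit. The step between these two compounds therefore cannot be read either: the limit of < 1000 nM in the physicochemical assay, at which 2 of the 2 values shown sit. The compounds shown leave open whether trifluoromethyl in place of bromo changes permeability or solubility at all.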